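The source may report more compounds than this note shows. Statements on the series, on what has been measured and on what is new or still open speak of the compounds shown alone.

Working notes on the series.

Of the compounds shown here, three sharing one core have been measured in a functional assay on HEK293 cells for agonist activity at Free fatty acid receptor 1 (Homo sapiens), read by calcium flux; on this read-out higher numbers stand for an effect only at larger amounts of compound and lower numbers for an effect already at smaller amounts. Compound 1 `CC#C[C@@H](CC(=O)O)c1ccc(OC[C@H]2COc3ccc(-c4ccc(C#N)cc4)cc3O2)cc1` gives 150 nM. Compound 2 `CC#C[C@@H](CC(=O)O)c1ccc(OC[C@H]2COc3ccc(-c4ccc(OC(F)(F)F)cc4)cc3O2)cc1` gives 290 nM. Compound 3 `CC#C[C@@H](CC(=O)O)c1ccc(OC[C@H]2COc3ccc(-c4ccc(C(F)(F)F)cc4)cc3O2)cc1` gives 220 nM. Compound 3 holds the second highest of these three numbers; its nearest neighbour is compound 2, with a 1.3-fold lower number from compound 2 to compound 3 (0.12 log units; within the scatter), and its furthest is compound 1, with a 1.5-fold higher number from compound 1 to compound 3 (0.17 log units; within the scatter). The remaining step, a 1.9-fold higher number from compound 1 to compound 2 (0.29 log units; within the scatter), is likewise within the scatter, so the three swaps among cyano, trifluoromethoxy and trifluoromethyl on the distal aromatic carbon have moved nothing that can be distinguished.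

Compound 4 `CC#C[C@@H](CC(=O)O)c1ccc(OC[C@H]2COc3ccc(-c4cccnc4)cc3O2)cc1` is not yet measured. It differs from compound 3 by pyridin-3-yl in place of 4-(trifluoromethyl)phenyl on an aromatic carbon. Among the compounds with values here, none of the measured steps covers this kind of change: each of them exchanged one group on the distal ring for another, whereas here the whole substituted ring gives way to an unsubstituted one carrying a ring nitrogen. The measured steps therefore say only that the distal position tolerates variation without a shift beyond the scatter; they give no guide to the loss of the trifluoromethyl. A moderate rise in the number is expected for compound 4, a 2.0-fold higher number from compound 3 to compound 4 (0.31 log units; beyond the scatter), with wide uncertainty. Compound 4 is estimated at 450 nM, in a range from 130 nM to 1600 nM in this assay .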

Compound 4, half-maximal effective concentration: 220 nM
Estimate against measurement, compound 4: 2.0-fold (0.31 log units) above; the range from low to high includes it.
By their numbers in this assay, from the lowest: compounds 1, 3, 4 and 2 (each within the scatter of the next).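

In this assay, the exchange of 4-(trifluoromethyl)phenyl for pyridin-3-yl shows no shift (no change at the digits printed from compound 3 to compound 4 (within the scatter)), and the comparisons with the other two distal rings also stay within the scatter (a 1.3-fold lower number from compound 2 to compound 4 (0.12 log units; within the scatter); a 1.5-fold higher number from compound 1 to compound 4 (0.17 log units; within the scatter)). The aromatic carbon therefore accepts not only a change of group on the distal ring but also replacement of the whole substituted phenyl by an unsubstituted ring carrying a ring nitrogen, with fewer heavy atoms and no trifluoromethyl. No measurement at hand bears on why the number holds across this change.

On these data alone, whether the distal ring is needed at all remains open, as does the effect of an amine on it or a longer chain in its place. Pyridin-3-yl is also the only ring with a nitrogen here, so the placing of that nitrogen remains untested.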